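Swapping a prenyl ether for a propanoate ester

This account rests on a few compounds, and the source may have more. Where it says the series, first, only, none or still open, it means among the compounds named here.

Compound 1 `COc1ccc(/C=C/C(=O)c2ccc(OC)c3c2OC(C)(C)C=C3)cc1OCC=C(C)C`: > 10000 nM in a functional assay on HepG2 cells (Homo sapiens) for cytotoxicity, read by MTT assay; a lower number here means a stronger inhibitor, a higher number a weaker inhibitor
Compound 2 `COc1ccc(/C=C/C(=O)c2ccc(OC)c3c2OC(C)(C)C=C3)cc1OCCO`: > 10000 nM

Compound 1 stands at a limit of the assay in this assay, with its value of > 10000 nM being a limit and not a number. Compound 2 likewise gives only a limit, > 10000 nM. Going by the values given here, the only measured step, a step that the two limits leave unreadable from compound 1 to compound 2, is therefore unreadable, as the limit of > 10000 nM in this assay, at which 2 of the 2 values shown sit, shows. Compound 3 `CCC(=O)Oc1cc(/C=C/C(=O)c2ccc(OC)c3c2OC(C)(C)C=C3)ccc1OC` differs from compound 1 by propanoyl in place of 3-methylbut-2-en-1-yl on an oxygen on an aromatic ring. Among the compounds with values here, no measured step can size this change, so compound 3 is expected to remain near the limit, with an estimate of 15000 nM (4000 nM to 60000 nM). The step expected for compound 3 is a step that the limit leaves unreadable from compound 1 to compound 3.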

Compound 3, half-maximal inhibitory concentration: 90 nM
Compound 3: the middle estimate sits 170-fold (2.22 log units) above what was measured; measured number below the stated range.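

Going by these compounds alone, on an oxygen on an aromatic ring, the earlier compounds showed no readable change, but propanoyl in place of 3-methylbut-2-en-1-yl gives an at least 110-fold lower number from compound 1 to compound 3 (2.04 log units; beyond the scatter) in this assay. Propanoyl in place of 2-hydroxyethyl gives an at least 110-fold lower number from compound 2 to compound 3 (2.04 log units; beyond the scatter). Both sizes are minimums, because compound 1 and compound 2 give limits and not numbers: the limit of > 10000 nM in this assay, at which 2 of the 3 values shown sit.

The compounds shown leave open how much the length of the propanoyl chain matters, as an acetyl or a butanoyl group on this oxygen would show. They also leave open whether an amide-linked chain or a chain ending in an amine would keep the number this low.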